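The compounds below may be only part of what the source reports. "The series", "measured", "known", "first", "only" and "open" are said of these compounds alone.

Measured in a functional assay on SK-OV-3 cells (Homo sapiens) for cytotoxicity; on this read-out lower numbers stand for stronger inhibition and higher numbers for weaker inhibition:
Compound 1 `C=C/C=C\[C@H](C)[C@H](OC(N)=O)[C@@H](C)[C@H](O)[C@@H](C)C/C(C)=C\[C@H](C)[C@@H](O)[C@@H](C)/C=C\CCc1ccc(C)c(O)c1`: 410 nM
Compound 2 `C=C/C=C\[C@H](C)[C@H](OC(N)=O)[C@@H](C)[C@H](O)[C@@H](C)C/C(C)=C\[C@H](C)[C@@H](O)[C@@H](C)/C=C\CCc1ccsc1`: 440 nM
Compound 3 `C=C/C=C\[C@H](C)[C@H](OC(N)=O)[C@@H](C)[C@H](O)[C@@H](C)C/C(C)=C\[C@H](C)[C@@H](O)[C@@H](C)/C=C\CCc1cccc(O)c1`: 40 nM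

Compound 3 stands lowest of the three on this assay. Compound 4 `C=C/C=C\[C@H](C)[C@H](OC(N)=O)[C@@H](C)[C@H](O)[C@@H](C)C/C(C)=C\[C@H](C)[C@@H](O)[C@@H](C)/C=C\CCc1cc(O)cc(O)c1` differs from it by hydroxy in place of hydrogen on an aromatic carbon, with hydroxy in place of hydrogen on an aromatic carbon. Among the compounds with values here, no measured step adds a hydroxy group, so the evidence is indirect. Within the data shown here, the nearest precedent is a 10-fold lower number from compound 1 to compound 3 (1.01 log units; beyond the scatter), a large step on the same ring, read in reverse: the added methyl goes with the higher number. an 11-fold lower number from compound 2 to compound 3 (1.04 log units; beyond the scatter) is also large, so this end of the molecule matters. A moderate rise is therefore expected, estimated as a 2.5-fold higher number from compound 3 to compound 4 (0.40 log units; beyond the scatter). For compound 4 the estimated value is 100 nM, with an expected range of 25 nM to 400 nM.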

Compound 4, half-maximal inhibitory concentration: 40 nM
Compound 4: middle estimate off by 2.5-fold (0.40 log units), on the high side; low and high end bracket the measured number.
By their numbers in this assay, from the lowest: compounds 3 and 4 (each within the scatter of the next); then compounds 1 and 2 (each within the scatter of the next).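

In this assay, hydroxy in place of hydrogen on an aromatic carbon, meta to a hydroxy group, gives a result with no rise in the number (no change at the digits printed from compound 3 to compound 4 (within the scatter)), so this ring carbon accepts the added group. The 3,5-dihydroxyphenyl compound also keeps the large gaps to the other two (an 11-fold lower number from compound 2 to compound 4 (1.04 log units; beyond the scatter); a 10-fold lower number from compound 1 to compound 4 (1.01 log units; beyond the scatter)). The rise seen with the added methyl of compound 1 therefore does not recur with this hydroxy. On these data alone, whether an amine or a methoxy group at this ring carbon would hold the number stays open. Nothing available explains why the added hydroxy is tolerated.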